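A few compounds are considered here, and "the series" means these few. Any claim that something is new, unique, unknown or untested is made for them only; others in the source may bear on it.

Working notes on the series. In a functional assay on K562 cells (Homo sapiens) for inhibition, read by trypan blue exclusion, with a stated time of 72 h (on this read-out higher numbers stand for weaker inhibition and lower numbers for stronger inhibition), compound 2 (`COc1ccc(S(=O)(=O)c2cc3cnc(Nc4ccc5[nH]ccc5c4)nc3n(C)c2=O)cc1`) gives 300 nM, the lower of the two numbers available. Compound 1 (`Cn1c(=O)c(S(=O)(=O)c2ccc(F)cc2F)cc2cnc(Nc3cccc4[nH]ccc34)nc21`) gives 1500 nM, and the gap between the two lies beyond the usual scatter.

Compound 3 (`COc1ccc(S(=O)(=O)c2cc3cnc(Nc4cccc5[nH]ccc45)nc3n(C)c2=O)cc1`) has the same atoms as compound 2, joined differently, with 1H-indol-4-yl in place of 1H-indol-5-yl on a nitrogen on an aromatic ring.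

Among the measured compounds shown here, no measured pair isolates this change, so its size in this assay can only be judged indirectly. For the measured compounds named here, the only guide is compound 1, which carries the same 1H-indol-4-yl group and gives 1500 nM. However, compound 1 also differs from compound 2 in the group on the sulfonyl, so the gap between them cannot be assigned to the indole alone.

A modest move toward weaker inhibition is therefore expected, of about the size given by a 1.7-fold higher number from compound 2 to compound 3 (0.22 log units; within the scatter), and it may not clear the scatter.

Compound 3 is estimated at 500 nM, with an expected range from 150 nM to 1600 nM.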

Compound 3, half-maximal inhibitory concentration: 5000 nM
Beside the measured number, compound 3's estimate is 10-fold (1.00 log units) below it; measured number above the stated range.
By their numbers in this assay, from the lowest: compound 2; then compound 1; then compound 3.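

In this assay the point of attachment of the indole on the amino nitrogen has a strong effect: with 4-methoxyphenyl held on the sulfonyl sulfur, 1H-indol-4-yl in place of 1H-indol-5-yl gives a 17-fold higher number from compound 2 to compound 3 (1.22 log units; beyond the scatter) and thus a large move toward weaker inhibition, so these two isomeric groups are not interchangeable at this position. Among the compounds shown here, with 1H-indol-4-yl held, 4-methoxyphenyl in place of 2,4-difluorophenyl gives a 3.3-fold higher number from compound 1 to compound 3 (0.52 log units; beyond the scatter) as a modest step, which for the first time reads the sulfonyl group apart from the indole and shows that both places affect the number. No measurement on hand accounts for either step.

Whether the indole step keeps its size with 2,4-difluorophenyl on the sulfonyl sulfur remains open, since a single pair defines it and the compounds shown do not test it against a second sulfonyl group. Also open, from the compounds shown here alone, are how 1H-indol-6-yl would compare on the same nitrogen and how an amine or a carboxylic acid on the sulfonyl aryl ring would shift the number.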